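The compounds below may be only part of what the source reports. "The series", "measured", "known", "first", "only" and "open" are said of these compounds alone.

Measured so far in an ADME assay on a cell-free system (plasma, Homo sapiens); a higher number here means a larger unbound share of the compound, a lower number a smaller unbound share
compound 1 `CCc1c(CN(C)CC(=O)O)cccc1-c1nsc(-c2ccc(OC(C)C)c(C(F)(F)F)c2)n1` gives 0.0049
compound 2 `CCc1c(CCCC(=O)O)cncc1-c1nsc(-c2ccc(OC(C)C)c(Cl)c2)n1` gives 0.0019
compound 3 `CCc1c(CN2CC(C(=O)O)C2)cccc1-c1nsc(-c2ccc(OC(C)C)c(Cl)c2)n1` gives 0.0096

Compound 2 has the lowest number of the three in this assay, and its gaps to both compound 1 and compound 3 lie beyond the scatter. Compound 4 `CCc1c(CCCC(=O)O)cncc1-c1nsc(-c2ccc(OC(C)C)c(C(F)(F)F)c2)n1` has not yet been measured. It keeps everything in compound 2 except for one place, with trifluoromethyl in place of chloro on an aromatic carbon.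

Within the data shown here, the measured set contains no pair that isolates this exchange. Compound 1 carries trifluoromethyl and compound 3 carries chloro, but the two also differ elsewhere, so their values offer no direct guide. As far as these compounds go, with the rest of compound 2 unchanged, no shift beyond the scatter is expected, and the direction remains open. The expected change is small (a 1.1-fold lower number from compound 2 to compound 4 (0.02 log units; within the scatter)). For compound 4 the estimated value is 0.0018 (expected range 0.0008 to 0.004).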

Compound 4, unbound fraction: 0.0012
Beside the measured number, compound 4's estimate is 1.5-fold (0.18 log units) above it; the measured number falls inside the stated range.
By their numbers in this assay, from the lowest: compounds 4 and 2 (each within the scatter of the next); then compounds 1 and 3 (each within the scatter of the next).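

Among these compounds, the pair formed by compound 2 and compound 4 is the first to isolate trifluoromethyl in place of chloro on this aromatic carbon, ortho to an isopropoxy group, and in this assay it gives a 1.6-fold lower number from compound 2 to compound 4 (0.20 log units; within the scatter). At this place, and with the rest of compound 2 unchanged, 4 heavy atoms entering for 1 leaves the unbound fraction within the scatter, so the two groups cannot be told apart here. Nothing shown gives a measured explanation for this result.

The compounds shown leave open whether a nitrile, a methyl or a methoxy group at this place would also stay within the scatter of compound 2. They also leave open whether the same exchange would read alike with the amine-bearing side chain of compound 3 in place of the butanoic acid chain.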